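Compound 2 at the limit, compound 4 to come

The compounds below may be only part of what the source reports. "The series", "measured", "known", "first", "only" and "open" are said of these compounds alone.

In a functional assay on HCT-116 cells (Homo sapiens) for cytotoxicity, read by MTT assay, with a stated time of 72 h (a lower number here means a stronger inhibitor, a higher number a weaker inhibitor), compound 1 (`O=S(=O)(c1ccccc1)c1nc2ccccc2nc1N1CCCC1`) gives 24200 nM and compound 3 (`O=S(=O)(c1ccc(Br)cc1)c1nc2ccccc2nc1N1CCCC1`) gives 37700 nM as measured numbers. Compound 2 (`COc1ccc(S(=O)(=O)c2nc3ccccc3nc2N2CCCC2)cc1`) stands at > 50000 nM as a limit of the assay and not a number. The measured steps exchange only hydrogen, methoxy and bromo on an aromatic carbon, and they run as an at least 2.0-fold higher number from compound 1 to compound 2 (0.31 log units; beyond the scatter) and as a 1.6-fold higher number from compound 1 to compound 3 (0.19 log units; within the scatter) and as an at least 1.3-fold lower number from compound 2 to compound 3 (0.12 log units; that floor lies within the scatter) in turn. Compound 4 (`COc1ccc(S(=O)(=O)c2nc3ccccc3nc2N2CCCC(O)C2)cc1`) keeps the methoxy group but carries 3-hydroxypiperidin-1-yl in place of pyrrolidin-1-yl on an aromatic carbon next to the ring nitrogen. For the measured compounds named here, none of the measured steps touches that place, so they bear on it only loosely, and no large step is expected in this assay beyond perhaps a slight move toward a lower number. The expected move is an at least 1.2-fold lower number from compound 2 to compound 4 (0.09 log units; that floor lies within the scatter) at this stage. For compound 4 the estimate is 40000 nM with an expected range from 15000 nM to 80000 nM in all.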

Compound 4, half-maximal inhibitory concentration: 3520 nM
Estimate against measurement, compound 4: 11-fold (1.06 log units) above; the whole stated range lies above it.
By their numbers in this assay, from the lowest: compound 4; then compounds 1 and 3 (each within the scatter of the next). At a limit, above all of these: compound 2.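

The earlier steps shown here exchanged only hydrogen, methoxy and bromo on an aromatic carbon, and none of them was large. For the compounds shown here, this change is the first at the place next to the ring nitrogen, and in this assay 3-hydroxypiperidin-1-yl in place of pyrrolidin-1-yl gives an at least 14-fold lower number from compound 2 to compound 4 (1.15 log units; beyond the scatter), which shows that this position can move the number much further than the earlier changes did. Compound 2 is held only as a limit of the assay, so the step gives a floor and not a full size: the limit of > 50000 nM in this assay, at which 1 of the 4 values shown sits.

The six-membered ring and the hydroxyl enter together, so the compounds shown do not tell which of them carries the step; a plain piperidin-1-yl or a 3-hydroxypyrrolidin-1-yl would separate the two. Going by these compounds, whether the same change holds with hydrogen or bromo in place of the methoxy also stays open.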